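Adding a benzimidazolylmethyl arm to the sulfonamide nitrogen

The source may report more compounds than this note shows. Statements on the series, on what has been measured and on what is new or still open speak of the compounds shown alone.

Two sulfonamides built on the same azobenzene core have been measured in an assay on isolated protein for inhibition of Aromatase (Homo sapiens), read by fluorescence; on this read-out lower numbers stand for stronger inhibition and higher numbers for weaker inhibition. Compound 1 `N#Cc1ccc(S(=O)(=O)Nc2ccc(/N=N/c3ccccc3)cc2)cc1` gives 7900 nM. Compound 2 `COc1ccc(S(=O)(=O)Nc2ccc(/N=N/c3ccccc3)cc2)c(OC)c1` gives 1600 nM, which is the lower of the two numbers, and the value of compound 1 lies above it by a margin beyond the scatter, so compound 2 stands as the stronger inhibitor of the pair.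

Compound 3 `COc1ccc(S(=O)(=O)N(Cc2nc3ccccc3[nH]2)c2ccc(/N=N/c3ccccc3)cc2)c(OC)c1` has not yet been measured. It differs from compound 2 in one place: (1H-benzimidazol-2-yl)methyl in place of hydrogen on a sulfonamide nitrogen. Going by the values given here, no measured pair shows what this kind of change does here, so the expectation rests on compound 2 alone. On that basis the step from compound 2 to compound 3 is expected to be a modest move toward stronger inhibition, a 2.3-fold lower number from compound 2 to compound 3 (0.36 log units; beyond the scatter), though a result within the scatter would not be surprising. Compound 3 is therefore estimated at 700 nM, with a plausible range from 150 nM to 3000 nM.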

Compound 3, half-maximal inhibitory concentration: 5700 nM
For compound 3 the middle estimate is 8.1-fold (0.91 log units) below the measured one, and the stated range ends below it.
By their numbers in this assay, from the lowest: compound 2; then compounds 3 and 1 (each within the scatter of the next).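

In this assay, the sulfonamide nitrogen can carry a large substituent and measurable inhibition remains, but the (1H-benzimidazol-2-yl)methyl arm gives no gain. Replacing the hydrogen with this arm brings a 3.6-fold higher number from compound 2 to compound 3 (0.55 log units; beyond the scatter), a modest weakening. No measurement shown here accounts for this loss.

This single step cannot separate the effect of losing the hydrogen from the effect of adding the arm with its 10 heavy atoms. Going by these compounds, it remains open whether a plain methyl on the same nitrogen, a benzyl group that lacks the benzimidazole nitrogens, or the benzimidazole joined through a longer chain would keep the inhibition of compound 2 or change it in either direction.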